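A few compounds are considered here, and "the series" means these few. Any claim that something is new, unique, unknown or untested is made for them only; others in the source may bear on it.

Compound 3 `COc1cc(/C=C/C(=O)OCc2c(-c3ccccc3)no[n+]2[O-])ccc1O` in a functional assay on NCI-H1299 cells (Homo sapiens) for cytotoxicity, read by resazurin assay, with a stated time of 72 h (a higher number here means a weaker inhibitor, a lower number a stronger inhibitor), gives 12900 nM. Compound 2 `O=C(/C=C/c1ccc(O)c(O)c1)OCc1c(-c2ccccc2)no[n+]1[O-]` in this assay returns only the limit of the assay, > 50000 nM. The change between them, (hydrogen in place of methyl on an oxygen on an aromatic ring), produces an at least 3.8-fold higher number from compound 3 to compound 2 (0.58 log units; beyond the scatter). Compound 1 `COc1cc(/C=C/C(=O)OCCCO[N+](=O)[O-])ccc1OCCCO[N+](=O)[O-]` in this assay likewise returns only the limit, > 50000 nM. How the core of compound 1 differs from the core of compound 3 is not broken down here. Compound 4 `O=C(/C=C/c1ccc(OCCCO[N+](=O)[O-])c(O)c1)OCCCO[N+](=O)[O-]` carries the same change relative to compound 1, (hydrogen in place of methyl on an oxygen on an aromatic ring). Within the data shown here, compound 1 already sits at the limit (the limit of > 50000 nM in this assay, at which 2 of the 3 values shown sit), and the one measured instance of this change gave an at least 3.8-fold higher number from compound 3 to compound 2 (0.58 log units; beyond the scatter). On that basis the expected step is a step that the limit leaves unreadable from compound 1 to compound 4, to a value that would again be reported only as a limit. Compound 4 is therefore estimated at 100000 nM, within a range from 40000 nM to 300000 nM.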

Compound 4, half-maximal inhibitory concentration: > 50000 nM
Compound 4: only a limit was reported; the forecaster's own chance of this, stated with the estimate: 90%; the middle value is on the limit's open side.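

In this assay compound 4 returns only a limit, > 50000 nM. Among these compounds, compound 1 is also held at a limit, so no step from compound 1 to compound 4 can be read. The compounds shown leave open how methoxy to hydroxy acts on the core of compound 1.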